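The source may report more compounds than this note shows. Statements on the series, on what has been measured and on what is new or still open speak of the compounds shown alone.

Two members of the series have been run in a functional assay on the whole organism for inhibition, with Rattus norvegicus as the target; on this read-out lower numbers stand for an effect already at smaller amounts and higher numbers for an effect only at larger amounts of compound. Compound 1 `CC1CC/C(=N\Nc2ccccc2Cl)c2ncc(C(=O)O)c(=O)n21` is the chloro member. In this assay compound 1 returns only the limit > 1000 umol/kg, not a number. Compound 2 `COc1ccccc1N/N=C1\CCC(C)n2c1ncc(C(=O)O)c2=O` differs from it by methoxy in place of chloro on an aromatic carbon. In this assay compound 2 likewise stops at the limit > 1000 umol/kg, again not a measured number. The step that the two limits leave unreadable from compound 1 to compound 2 stays without a size because both ends sit at the limit of > 1000 umol/kg in this assay, at which 2 of the 2 values shown sit. Compound 2 thus stands at the reporting limit of this assay, with no measured number anywhere in the series to compare against.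

Compound 3 `Cc1cccc(N/N=C2\CCC(C)n3c2ncc(C(=O)O)c3=O)c1` is the next variation: 3-methylphenyl in place of 2-methoxyphenyl on an amine nitrogen. Going by the values given here, no measured step bears on an exchange of this kind; the single step recorded was itself unreadable, so nothing indicates a shift in either direction beyond the scatter. Compound 3 is accordingly expected to return a limit rather than a number in this assay, estimated at 2000 umol/kg, spanning 600 umol/kg to 8000 umol/kg. For compound 3 the expected step is a step that the limit leaves unreadable from compound 2 to compound 3.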

Compound 3, dose for 50% inhibition: 72.5 umol/kg
Compound 3: middle estimate off by 28-fold (1.44 log units), on the high side; measured number outside the range, below it.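

On an amine nitrogen, the aryl group can move the read-out in this assay, which the earlier pair could not show: the step between them cannot be read, whereas 3-methylphenyl in place of 2-methoxyphenyl gives an at least 13-fold lower number from compound 2 to compound 3 (1.13 log units; beyond the scatter), and 3-methylphenyl in place of 2-chlorophenyl gives an at least 13-fold lower number from compound 1 to compound 3 (1.13 log units; beyond the scatter). Compound 3, at 72.5 umol/kg, is the only member shown with a measured number, so it is the first fixed reference point for this position. Both step sizes are lower bounds only, and the true distance to the two earlier compounds remains unknown: the limit of > 1000 umol/kg in this assay, at which 2 of the 3 values shown sit.

Each exchange changes the substituent and its place on the aromatic ring together, so the compounds shown do not tell whether the lower number follows the methyl group or its placement; 2-methylphenyl, 3-methoxyphenyl and 3-chlorophenyl would separate these two readings. Also open, going by these compounds, is how far the series extends beyond this one number, for instance whether unsubstituted phenyl or 3-ethylphenyl on the same amine nitrogen would keep a measurable effect in this assay.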